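A few compounds are considered here, and "the series" means these few. Any claim that something is new, unique, unknown or untested is made for them only; others in the source may bear on it.

Among the compounds with values here, compound 1 `O=C(COC(=O)/C=C/c1ccccc1)NCCC[Te]c1ccccc1` is the only measured compound that returns a number in an ADME assay on cells (Fibroblast, Homo sapiens) for cytotoxicity, read by MTT assay, with a stated time of 24 h (on this read-out higher numbers stand for weaker inhibition and lower numbers for stronger inhibition), where compound 1 gives 11000 nM. Compound 2 `COc1ccc(N(CC(=O)NCCC[Se]c2ccccc2)C(=O)/C=C/c2ccccc2)cc1` in this assay gives >= 100000 nM, which is a limit of the assay rather than a number. Compound 3 `COc1ccc(N(CC(=O)NCCC[Se]c2ccccc2)C(=O)C#Cc2ccccc2)cc1` in this assay likewise gives only the limit >= 100000 nM. The change from compound 2 to compound 3 is 2-phenylethynyl in place of 2-phenylethenyl on a carbonyl carbon, and because both values sit at the limit of >= 100000 nM in this assay, at which 2 of the 3 values shown sit, the step that the two limits leave unreadable from compound 2 to compound 3 cannot be read. How the cores of compound 1 and compound 2 differ is not broken down here. Compound 4 `O=C(COC(=O)C#Cc1ccccc1)NCCC[Te]c1ccccc1`, not yet measured, carries the same kind of change, (2-phenylethynyl in place of 2-phenylethenyl on a carbonyl carbon); the place differs, since in compound 3 the other neighbour of the carbonyl carbon is amide-type nitrogen, while in compound 4 it is oxygen next to a carbonyl group. With no readable step available, the expectation rests only on the value 11000 nM of compound 1, and a step of no change at the digits printed from compound 1 to compound 4 (within the scatter) is expected. Compound 4 is estimated at 11000 nM, between 4000 nM and 35000 nM.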

Compound 4, half-maximal inhibitory concentration: 7000 nM
The estimate for compound 4 lay 1.6-fold (0.20 log units) above the measured number; measured number inside the range.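

In this assay, putting 2-phenylethynyl in place of 2-phenylethenyl on a carbonyl carbon whose other neighbour is oxygen next to a carbonyl group gives a 1.6-fold lower number from compound 1 to compound 4 (0.20 log units; within the scatter), so on this core the two groups cannot be told apart. The same change on the other core, with an amide-type nitrogen on the carbonyl carbon, cannot be read, because compound 2 and compound 3 each give a limit and not a number: the limit of >= 100000 nM in this assay, at which 2 of the 4 values shown sit. The change therefore has a readable result on one core only, and nothing shows whether it carries over to the other.

Still open, from the compounds shown here alone, is how a saturated 2-phenylethyl group on the same carbonyl carbon would read on the core of compound 1. Also open, going by these compounds, is what an amine on the phenyl ring of that group would do.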